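Working notes: from compound 1 toward compound 4

The source may report more compounds than this note shows. Statements on the series, on what has been measured and on what is new or still open speak of the compounds shown alone.

Measured so far:
compound 1 `CC(C)(C)OC(=O)NC1CCN(C(=O)CN2CN(c3ccccc3)C3(CCN(C(=O)c4ccc(C(C)(C)C)cc4)CC3)C2=O)CC1`: 8300 nM
compound 2 `CC(C)(C)OC(=O)NC1CCN(C(=O)CN2CN(c3ccccc3)C3(CCN(C(=O)c4ccc(C5CCCCC5)cc4)CC3)C2=O)CC1`: 4800 nM
compound 3 `COC(=O)CCNC(=O)CN1CN(c2ccccc2)C2(CCN(C(=O)c3ccc(C(C)(C)C)cc3)CC2)C1=O`: "not determined" (no result reported)

In an assay on HEK293 cells for displacement of a labelled ligand from NPC1-like intracellular cholesterol transporter 1 (Homo sapiens) (a lower number here means a stronger inhibitor, a higher number a weaker inhibitor), compound 1 gives 8300 nM, the higher of the two numbers measured; compound 2 gives 4800 nM, and the two lie within the scatter of each other. Compound 3 has no result reported. Within the data shown here, the only measured step, a 1.7-fold lower number from compound 1 to compound 2 (0.24 log units; within the scatter), concerns the substituent on the aromatic carbon and not the part altered here.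

Compound 4 `CCc1nn(CC)c(C2CCN(C(=O)CN3CN(c4ccccc4)C4(CCN(C(=O)c5ccc(C(C)(C)C)cc5)CC4)C3=O)CC2)c1CC` differs from compound 1 by 1,3,4-triethyl-1H-pyrazol-5-yl in place of (tert-butoxycarbonyl)amino on a saturated ring carbon. Among the measured compounds shown here, no measured step touches this position, so neither the direction nor the size of the change can be read from the data. In the absence of any bearing step, compound 4 is expected near 6000 nM, with a range of 1500 nM to 25000 nM. The step implied, a 1.4-fold lower number from compound 1 to compound 4 (0.14 log units; within the scatter), is an expectation that stays within the scatter.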

Compound 4, half-maximal inhibitory concentration: 4600 nM
Compound 4: the middle estimate sits 1.3-fold (0.12 log units) above what was measured; low and high end bracket the measured number.
By their numbers in this assay, from the lowest: compounds 4, 2 and 1 (each within the scatter of the next).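

At this position on the saturated ring carbon, 1,3,4-triethyl-1H-pyrazol-5-yl in place of (tert-butoxycarbonyl)amino gives a 1.8-fold lower number from compound 1 to compound 4 (0.26 log units; within the scatter), so this large exchange, which also removes the hydrogen-bond donor, leaves the number within the scatter. No measured evidence bears on the reason for this result. As far as these compounds go, it remains open whether a free primary amine or a carboxylic acid on this ring carbon would move the number beyond the scatter, and whether a pyrazole without the three ethyl groups would keep it there.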